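Swapping 4-nitrophenyl for 3,5-dichlorophenyl in compound 2

The source may hold more compounds than are shown below. What is called first, only, known or untested is meant among the compounds shown, and "the series" means these compounds.

- compound 1 (`O=C(NCCNS(=O)(=O)c1ccc(-c2ccccc2O[C@H]2CC[C@@H](O)CC2)s1)Nc1ccc([N+](=O)[O-])cc1`) gives > 20000 nM as a limit
- compound 2 (`O=C(NCCNS(=O)(=O)c1ccc(-c2ccccc2O[C@H]2CC[C@H](O)CC2)s1)Nc1ccc([N+](=O)[O-])cc1`) gives 10500 nM as a number
- compound 3 (`O=C(NCCNS(=O)(=O)c1ccc(-c2ccccc2Oc2ccc([N+](=O)[O-])c([N+](=O)[O-])c2)s1)Nc1ccc([N+](=O)[O-])cc1`) gives > 20000 nM as a limit

Going by the values given here, in a functional assay on HeLa cells (Homo sapiens) for inhibition, read by CCK-8 assay, with a stated time of 48 h (on this read-out higher numbers stand for weaker inhibition and lower numbers for stronger inhibition), compound 2 gives the only true number (10500 nM). The other two values are limits. Compound 4 (`O=C(NCCNS(=O)(=O)c1ccc(-c2ccccc2O[C@H]2CC[C@H](O)CC2)s1)Nc1cc(Cl)cc(Cl)c1`) differs from compound 2 in one place (3,5-dichlorophenyl in place of 4-nitrophenyl on an amide-type nitrogen), with 3,5-dichlorophenyl in place of 4-nitrophenyl on an amide-type nitrogen. Among the compounds with values here, no measured step changes this group. One nearby step is an at least 1.9-fold lower number from compound 1 to compound 2 (0.27 log units; that floor lies within the scatter) for a change of configuration only. The other is an at least 1.9-fold higher number from compound 2 to compound 3 (0.27 log units; that floor lies within the scatter) for a change on an oxygen on an aromatic ring. Both are floors within the scatter, so no step beyond the scatter is expected in this assay in either direction (a 1.1-fold lower number from compound 2 to compound 4 (0.02 log units; within the scatter)). Compound 4 is estimated at 10000 nM with 3500 nM to 20000 nM (the expected range).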

Compound 4, half-maximal inhibitory concentration: > 20000 nM
Compound 4: a limit, no number (the forecaster's own chance of this, stated with the estimate: 25%); middle value at least 2.0-fold (0.30 log units) from the limit.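

Going by these compounds alone, compound 4 gives the first view of a change on the amide-type nitrogen: in this assay, 3,5-dichlorophenyl in place of 4-nitrophenyl gives an at least 1.9-fold higher number from compound 2 to compound 4 (0.27 log units; that floor lies within the scatter). The value of compound 4 is a limit, not a number, so this step does not show that 4-nitrophenyl is needed here. The size of the step cannot be read, because compound 4 sits at the same limit as compounds 1 and 3: the limit of > 20000 nM in this assay, at which 3 of the 4 values shown sit.

Still open, on these data alone, is whether a group such as 4-aminophenyl or methyl on this nitrogen would give a lower number than compound 2, at 10500 nM.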